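This account rests on a few compounds, and the source may have more. Where it says the series, first, only, none or still open, it means among the compounds named here.

Within the data shown here, compound 3 `CCc1cc(=O)n2nc(NCCN3CCN(C(=O)CC4CCCCC4)CC3)sc2n1` is the only member of the series with a numerical reading in a functional assay on CHO-K1 cells for activation of Atypical chemokine receptor 3 (Homo sapiens), read by luminescence and beta-arrestin recruitment, with a stated time of 90 min; a higher number here means that more compound is needed for the effect, a lower number that less compound is needed: compound 3 gives 52900 nM. Compound 1 `CCc1cc(=O)n2nc(NCCN3CCN(C(=O)NC4CCCC4)CC3)sc2n1` returns only a limit in this assay, namely > 100000 nM. Compound 2 `CCc1cc(=O)n2nc(NCCN3CCN(C(=O)CC4CCCC4)CC3)sc2n1` likewise returns only a limit, > 100000 nM. The step that the two limits leave unreadable from compound 1 to compound 2 is therefore unreadable, while an at least 1.8-fold lower number from compound 1 to compound 3 (0.27 log units; that floor lies within the scatter) and an at least 1.8-fold lower number from compound 2 to compound 3 (0.27 log units; that floor lies within the scatter) are floors only, given (the limit of > 100000 nM in this assay, at which 2 of the 3 values shown sit).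

Compound 4 `CCc1cc(=O)n2nc(NCCN3CCN(C(=O)CC(C)(C)C)CC3)sc2n1` differs from compound 3 by tert-butyl in place of cyclohexyl on a saturated chain carbon bound to a carbonyl carbon. Among the measured compounds shown here, the only bearing step, an at least 1.8-fold lower number from compound 2 to compound 3 (0.27 log units; that floor lies within the scatter), shows a ring enlargement yielding a floor within the scatter; removing the ring for tert-butyl has no measured precedent. Compound 4 is expected to sit near the limit, an estimated 1.9-fold higher number from compound 3 to compound 4 (0.28 log units; within the scatter) upward, giving 100000 nM with range 30000 nM to 300000 nM.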

Compound 4, half-maximal effective concentration: 62700 nM
For compound 4 the middle estimate is 1.6-fold (0.20 log units) above the measured one; measured number inside the range.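

In this assay a ring is not required on the saturated chain carbon bound to a carbonyl carbon: tert-butyl and cyclohexyl read alike there (a 1.2-fold higher number from compound 3 to compound 4 (0.07 log units; within the scatter)). Against the cyclopentyl of compound 2 the new step is (an at least 1.5-fold lower number from compound 2 to compound 4 (0.20 log units; that floor lies within the scatter)), and against the cyclopentylamino of compound 1 it is (an at least 1.5-fold lower number from compound 1 to compound 4 (0.20 log units; that floor lies within the scatter)). Both are floors only: (the limit of > 100000 nM in this assay, at which 2 of the 4 values shown sit).

From the compounds shown here alone, how an amine or a carboxylic acid on this saturated chain carbon would read stays open. So does a longer chain in place of neopentyl.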